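The compounds below may be only part of what the source reports. "The series", "measured", "known", "first", "only" and "open" are said of these compounds alone.

Measured so far, in an assay on SH-EP1 cells for displacement of a labelled ligand from Neuronal acetylcholine receptor; alpha4/beta2 (Homo sapiens), read by scintillation counting; a higher number here means a weaker inhibitor, a lower number a stronger inhibitor:
compound 1 `CC(=O)N1CC2CC(C1)N2`: 150 nM
compound 2 `O=C([C@@H]1C[C@@H]1F)N1CC2CC(C1)N2`: 1.7 nM

Compound 2 stands at the lowest number of the two; the nearest is compound 1, separated by an 88-fold lower number from compound 1 to compound 2 (1.95 log units; beyond the scatter), the change being 2-fluorocyclopropyl in place of methyl on a carbonyl carbon. Compound 3 `C[C@H]1C[C@H]1C(=O)N1CC2CC(C1)N2` is not yet measured in this assay. It differs from compound 2 by methyl in place of fluoro on a saturated ring carbon; cut one bond further out, the same difference reads 2-fluorocyclopropyl to 2-methylcyclopropyl.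

For the measured compounds named here, only one measured step exists, an 88-fold lower number from compound 1 to compound 2 (1.95 log units; beyond the scatter), and it exchanges the whole substituent on the carbonyl carbon rather than a single group on the three-membered ring. Going by the values given here, no measured pair shows what the fluoro by itself contributes, so the large step does not carry over directly; it shows only that the cyclopropyl-bearing compound 2 lies far from compound 1. Within the substituted cyclopropyl pair, the swap of fluoro for methyl is expected to move this assay little, perhaps toward a slightly higher number: a 1.8-fold higher number from compound 2 to compound 3 (0.25 log units; within the scatter). Compound 3 is estimated at 3 nM, with a range of 1 nM to 10 nM.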

Compound 3, inhibition constant: 7 nM
The estimate for compound 3 lay 2.3-fold (0.37 log units) below the measured number; the range from low to high includes it.
By their numbers in this assay, from the lowest: compound 2; then compound 3; then compound 1.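

In this assay, the group on the saturated ring carbon matters: a 4.1-fold higher number from compound 2 to compound 3 (0.61 log units; beyond the scatter), so even this exchange of one heavy atom for another moves the number beyond the scatter, with fluoro giving the lower number of the two. The large gain over the methyl on the carbonyl carbon does not depend on fluoro, since the 2-methylcyclopropyl group also gives a 21-fold lower number from compound 1 to compound 3 (1.33 log units; beyond the scatter); both substituted cyclopropyl compounds shown therefore lie well below compound 1, and neither goes against this. No measurement at hand accounts for the difference between fluoro and methyl at this position.

From the compounds shown here alone, the contribution of the cyclopropyl ring alone remains open, as an unsubstituted cyclopropyl on the carbonyl carbon would be needed to show whether fluoro lowers the number or methyl raises it. Also open, going by these compounds, are how a chloro, hydroxyl or trifluoromethyl on the same ring carbon would read in this assay, and how other stereoisomers of these cyclopropyl groups would compare.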